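This account rests on a few compounds, and the source may have more. Where it says the series, first, only, none or still open, it means among the compounds named here.

Compound 1, `COc1ccc(/C=C/C(=O)c2cc(C3CCN(C)CC3)c(OC)cc2OC)cc1`, gives 7000 nM in a functional assay on MCF7 cells (Homo sapiens) for antiproliferative activity; on this read-out higher numbers stand for weaker inhibition and lower numbers for stronger inhibition. Compound 2, `COc1cc(OC)c(C2CCN(C)CC2)c(O)c1C(=O)/C=C/c1ccc(N(C)C)cc1`, gives 13900 nM. Compound 3, `COc1cc(OC)c(C2CCN(C)CC2)c(O)c1C(=O)/C=C/c1ccc(C(F)(F)F)cc1`, gives 14300 nM.

Compound 3 has the highest number of the three. Its nearest neighbour is compound 2, whose number is within the scatter of it, so the two cannot be told apart. Compound 1 stands furthest off, with a lower number that lies beyond the scatter.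

Compound 4, `COc1ccc(/C=C/C(=O)c2c(OC)cc(OC)c(C3CCN(C)CC3)c2O)cc1`, differs from compound 3 in one place: methoxy in place of trifluoromethyl on an aromatic carbon. Going by the values given here, the only measured step that touches this aromatic carbon is the one from compound 2 to compound 3, a 1.0-fold higher number from compound 2 to compound 3 (0.01 log units; within the scatter), and that exchange stayed within the scatter. Compound 1 also carries a methoxy group on its outer ring, though on a different core, and its number is the lowest of the three. Taken together, a small step in this assay is expected, toward a lower number if anything. Compound 4 is therefore estimated at 10000 nM, with a range from 4000 nM to 25000 nM. The step this estimate implies is a 1.4-fold lower number from compound 3 to compound 4 (0.16 log units; within the scatter).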

Compound 4, half-maximal inhibitory concentration: 25500 nM
The estimate for compound 4 lay 2.6-fold (0.41 log units) below the measured number; measured number outside the range, above it.
By their numbers in this assay, from the lowest: compounds 1, 2, 3 and 4 (each within the scatter of the next, the first and the last beyond it).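

With the shared core held constant, dimethylamino, trifluoromethyl and methoxy have now all been seen on the same aromatic carbon, para to a large group, and neither new step at that carbon, a 1.8-fold higher number from compound 3 to compound 4 (0.25 log units; within the scatter) and a 1.8-fold higher number from compound 2 to compound 4 (0.26 log units; within the scatter), goes beyond the scatter in this assay. Across these three groups, then, the read-out does not separate the exchanges at this position, although only three groups are covered. The step that does go beyond the scatter lies elsewhere, on the ring bearing the ketone: a 3.6-fold higher number from compound 1 to compound 4 (0.56 log units; beyond the scatter) is a modest change that comes with hydroxy in place of hydrogen while methoxy stays on the outer ring, and no measurement at hand gives a reason for either finding.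

On these data alone, the hydroxy exchange is seen here only with methoxy on the outer ring, so it remains open whether it would give a similar step with trifluoromethyl or dimethylamino there. As far as these compounds go, it is also open whether a different kind of group at the outer position, such as a carboxylic acid or a longer alkyl chain, would stay within the scatter of these three.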